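The source may report more compounds than this note shows. Statements on the series, on what has been measured and on what is new or still open speak of the compounds shown alone.

Measured compounds:
- Compound 1 `Cc1ccc(-n2nc(-c3ccc(C(F)(F)F)cc3O)nc2-c2ccccc2O)cc1`: 113000 nM
- Compound 2 `Oc1cc(C(F)(F)F)ccc1-c1nc(-c2ccccc2O)n(-c2ccc(I)cc2)n1`: 73300 nM
- Compound 3 `COc1cccc(-n2nc(-c3ccc(C(F)(F)F)cc3O)nc2-c2ccccc2O)c1`: 56400 nM

All three compounds share one core and differ only in the aromatic group on a ring nitrogen. In a toxicity assay on PC-12 cells (Rattus norvegicus) for cytotoxicity, read by MTT assay (on this read-out higher numbers stand for weaker inhibition and lower numbers for stronger inhibition), compound 3 gives 56400 nM, which lies within the usual scatter of both other values, so the three cannot be ranked.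

Compound 4 `Cc1ccc(-n2nc(-c3ccc(C(F)(F)F)cc3O)nc2-c2ccccc2O)c(C)c1` keeps the same core and has 2,4-dimethylphenyl in place of 3-methoxyphenyl on an aromatic nitrogen.

For the measured compounds named here, no measured compound carries this exact group, but three measured steps change the same position. They are a 1.5-fold lower number from compound 1 to compound 2 (0.19 log units; within the scatter), a 2.0-fold lower number from compound 1 to compound 3 (0.30 log units; within the scatter) and a 1.3-fold lower number from compound 2 to compound 3 (0.11 log units; within the scatter). All three are small, so swapping this group has so far not moved the read-out beyond the scatter. The closest measured group is the 4-methylphenyl of compound 1, which gives 113000 nM. This points, if anywhere, toward a somewhat higher number in this assay, though no step beyond the scatter is expected.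

The expected change is a 1.4-fold higher number from compound 3 to compound 4 (0.15 log units; within the scatter).

For compound 4, the estimated value is 80000 nM, with an expected range from 35000 nM to 180000 nM.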

Compound 4, half-maximal inhibitory concentration: 231000 nM
Compound 4: the middle estimate sits 2.9-fold (0.46 log units) below what was measured, and the stated range ends below it.
By their numbers in this assay, from the lowest: compounds 3, 2 and 1 (each within the scatter of the next); then compound 4.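

In this assay this position can move the read-out beyond the scatter, which none of the three earlier steps did: 2,4-dimethylphenyl in place of 3-methoxyphenyl gives a 4.1-fold higher number from compound 3 to compound 4 (0.61 log units; beyond the scatter) and, in place of 4-iodophenyl, it gives a 3.2-fold higher number from compound 2 to compound 4 (0.50 log units; beyond the scatter) on the same aromatic nitrogen. The smallest change is the most striking, since a single methyl in place of hydrogen on an aromatic carbon gives a 2.0-fold higher number from compound 1 to compound 4 (0.31 log units; beyond the scatter) and makes compound 4 the weakest inhibitor of the four, with its steps to all three others beyond the scatter. Nothing available here explains this shift.

From the compounds shown here alone, all four groups at this position are substituted phenyl rings carrying methyl, iodo or methoxy, so it remains open how the read-out would respond to an amine or a carboxylic acid on that ring, or to a cyclohexyl group replacing the ring altogether. With only one cell-based read-out shown, it also remains open whether the higher number of compound 4 would carry over to any other assay.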